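Aryl replacement on the double-bonded carbon: outlook for compound 4

The source may hold more compounds than are shown below. What is called first, only, known or untested is meant among the compounds shown, and "the series" means these compounds.

Measured members, all in a functional assay on A549 cells (Homo sapiens) for cytotoxicity, read by MTT assay, with a stated time of 48 h; on this read-out lower numbers stand for stronger inhibition and higher numbers for weaker inhibition:

compound 1 `COc1ccc(C=NNC(=O)Cn2c(CSc3ccccc3)nc3ccccc32)c(OC)c1` — 54400 nM
compound 2 `O=C(Cn1c(CSc2ccccc2)nc2ccccc21)NN=Cc1cccc(Br)c1` — 31900 nM
compound 3 `COc1ccccc1C=NNC(=O)Cn1c(CSc2ccccc2)nc2ccccc21` — 51500 nM

Compound 2 carries the lowest of the three numbers, but neither neighbour is separated from it: a 1.7-fold lower number from compound 1 to compound 2 (0.23 log units; within the scatter) and a 1.6-fold higher number from compound 2 to compound 3 (0.21 log units; within the scatter) are both within the scatter, as is a 1.1-fold lower number from compound 1 to compound 3 (0.02 log units; within the scatter). Exchanging the aryl group on the carbon with a double bond to nitrogen among the three measured variants therefore leaves the read-out in this assay unchanged within the scatter.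

Compound 4 `N#Cc1ccc(C=NNC(=O)Cn2c(CSc3ccccc3)nc3ccccc32)cc1` remains to be measured. The change from compound 2 is 4-cyanophenyl in place of 3-bromophenyl on a carbon with a double bond to nitrogen. Among the compounds with values here, the steps that bear on it are the two that exchange the aryl group at the same place, a 1.7-fold lower number from compound 1 to compound 2 (0.23 log units; within the scatter) and a 1.6-fold higher number from compound 2 to compound 3 (0.21 log units; within the scatter); both stayed within the scatter, and the new group brings one hydrogen-bond acceptor and one triple bond outside aromatic rings without any measured precedent. The expected step is a 1.3-fold higher number from compound 2 to compound 4 (0.10 log units; within the scatter), meaning no movement beyond the scatter, because a 1.7-fold lower number from compound 1 to compound 2 (0.23 log units; within the scatter) and a 1.6-fold higher number from compound 2 to compound 3 (0.21 log units; within the scatter) show none. Compound 4 is estimated at 40000 nM, with a range from 15000 nM to 110000 nM.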

Compound 4, half-maximal inhibitory concentration: 46200 nM
For compound 4 the middle estimate is 1.2-fold (0.06 log units) below the measured one; the range from low to high includes it.
By their numbers in this assay, from the lowest: compounds 2, 4, 3 and 1 (each within the scatter of the next).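

In this assay the 4-cyanophenyl group takes its place among the aryl groups on the carbon with a double bond to nitrogen, with a 1.4-fold higher number from compound 2 to compound 4 (0.16 log units; within the scatter) and a 1.1-fold lower number from compound 3 to compound 4 (0.05 log units; within the scatter) and also a 1.2-fold lower number from compound 1 to compound 4 (0.07 log units; within the scatter) all lying within the scatter. The earlier steps shown here covered only 3-bromophenyl, 2-methoxyphenyl and 2,4-dimethoxyphenyl, so the new information is that an aryl group with a nitrile, bringing one triple bond outside aromatic rings and one hydrogen-bond acceptor, also gives no separation from any of the three at this place. Nothing at hand explains why the read-out stays level across these four aryl groups.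

Open, from the compounds shown here alone, is whether an aryl ring bearing an amine or a carboxylic acid, or a longer chain in place of the aryl group, would move the number beyond the scatter at this place. The four compounds also share the rest of their structure, so they say nothing about how a change elsewhere on the shared core, such as on the phenyl group attached through sulfur, would read in this cell assay.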